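This account rests on a few compounds, and the source may have more. Where it says the series, first, only, none or still open, it means among the compounds named here.

Measured compounds:
- compound 1, `O=C(O)c1nn(Cc2cc(Br)ccc2OCc2ccccc2)cc1C(F)(F)F`: < 2000 nM
- compound 2, `O=C(O)c1nn(Cc2cc(Br)ccc2OCc2ccccc2)cc1Cl`: < 2000 nM
- compound 3, `Cc1cc(C(=O)O)nn1Cc1cc(Br)ccc1OCc1ccc(Cl)cc1`: 8.71 nM

All three were tested in a functional assay on CHO-K1 cells for antagonist activity at prostaglandin E2 receptor EP1 subtype (Homo sapiens), read by FLIPR; on this read-out lower numbers stand for stronger inhibition and higher numbers for weaker inhibition. Going by the values given here, compound 3 is the only one with an actual number; in this assay compound 3 gives 8.71 nM. The value of compound 1 is a limit of the assay, not a number. The value of compound 2 is likewise only a limit. Among the compounds with values here, the single measured step, from compound 1 to compound 2 , is therefore a step that the two limits leave unreadable from compound 1 to compound 2; both ends sit at the limit of < 2000 nM in this assay, at which 2 of the 3 values shown sit, so its size cannot be read.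

Compound 4 , `Cc1cccc(COc2ccc(Br)cc2Cn2nc(C(=O)O)cc2C)c1`, differs from compound 3 by 3-methylphenyl in place of 4-chlorophenyl on a saturated chain carbon bound to an oxygen on an aromatic ring. Within the data shown here, no measured step touches this part of the molecule: the one step recorded changes a group on the shared core, not the benzyl group, and its size is unreadable anyway. The change itself swaps one small substituent on the outer phenyl ring for another of the same count of heavy atoms, with no change in donors, acceptors or charge. With nothing to point the other way, the expected step from compound 3 to compound 4 is a 1.7-fold higher number from compound 3 to compound 4 (0.24 log units; within the scatter), that is, no change beyond the usual scatter. Compound 4 is therefore estimated at 15 nM, with a range from 4 nM to 60 nM.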

Compound 4, inhibition constant: 525 nM
The estimate for compound 4 lay 35-fold (1.54 log units) below the measured number; the whole stated range lies below it.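

Changing 4-chlorobenzyl to 3-methylbenzyl gives, in this assay, a 60-fold higher number from compound 3 to compound 4 (1.78 log units; beyond the scatter). The group that leaves and the group that enters have the same count of heavy atoms, and neither carries a hydrogen-bond donor, an acceptor or a net charge, so those counts alone do not tell how well a group at this position will be tolerated. Going by these compounds alone, the one earlier step cannot be read, since both of its ends are limits of the assay, which makes this the first readable step and shows that the outer phenyl ring of the benzyl group is a sensitive place in the molecule, though nothing measured here accounts for the size of the step.

The change swaps chlorine for methyl and also moves the substituent on the ring, so these two compounds cannot show which of the two differences carries the step. As far as these compounds go, what remains open is how 3-chlorophenyl, 4-methylphenyl or a phenyl ring bearing a nitrile or methoxy group would read at this position.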